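Configuration step from compound 3 to compound 4

The source may hold more compounds than are shown below. What is called first, only, known or untested is meant among the compounds shown, and "the series" means these compounds.

- compound 1 `CC(C)C[C@H]1C(=O)N[C@@H](CCCCNC(=O)OCc2ccccc2)C(=O)N[C@@H](Cc2ccccc2)C(=O)N(C)[C@H](Cc2ccccc2)C(=O)N[C@@H](C(C)C)C(=O)N1C` gives 3900 nM
- compound 2 `CC(C)C[C@@H]1NC(=O)[C@H](Cc2ccccc2)NC(=O)[C@@H](Cc2ccccc2)N(C)C(=O)[C@@H](CCCCNC(=O)OCc2ccc(Cl)cc2)NC(=O)[C@H](C(C)C)NC1=O` gives 2900 nM
- compound 3 `CC(C)C[C@@H]1NC(=O)[C@@H]([C@H](OCc2ccccc2)c2ccccc2)NC(=O)[C@@H](Cc2ccccc2)NC(=O)[C@@H](CC(C)C)NC(=O)[C@H](C(C)C)N(C)C1=O` gives 3200 nM

In a functional assay on HCT-116 cells (Homo sapiens) for cytotoxicity, read by hypoxanthine incorporation, with a stated time of 72 h (on this read-out higher numbers stand for weaker inhibition and lower numbers for stronger inhibition), compound 3 stands at 3200 nM and lies within the usual scatter of both compound 1 and compound 2, so these three values give no ranking. The next compound to be measured is compound 4 `CC(C)C[C@@H]1NC(=O)[C@H]([C@@H](OCc2ccccc2)c2ccccc2)NC(=O)[C@@H](Cc2ccccc2)NC(=O)[C@@H](CC(C)C)NC(=O)[C@H](C(C)C)N(C)C1=O`, which has not yet been tested. Compared with compound 3, compound 4 shows this difference: the two compounds have the same atoms and bonds and differ only in configuration as drawn: 2 of 6 stereo elements differ; a stereocentre at a saturated ring carbon is drawn R in compound 3 and S in compound 4; a stereocentre at a saturated chain carbon is drawn R in compound 3 and S in compound 4, with nothing leaving and nothing entering.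

Among the measured compounds shown here, no two measured compounds differ in a single place, so the series offers no direct precedent for the size or direction of this configuration change. For the measured compounds named here, with no measured step to draw on, no shift beyond the scatter is expected as the central case, although a shift in either direction remains possible and the range is kept wide. The estimated step of a 1.1-fold higher number from compound 3 to compound 4 (0.04 log units; within the scatter) is expected to stay within the scatter. This expectation starts from compound 3 at 3200 nM and has no other direct support. In this assay compound 4 is estimated at 3500 nM with an expected range of 1300 nM to 10000 nM for repeated measurements.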

Compound 4, half-maximal inhibitory concentration: 5800 nM
Beside the measured number, compound 4's estimate is 1.7-fold (0.22 log units) below it; the measured number falls inside the stated range.
By their numbers in this assay, from the lowest: compounds 2, 3, 1 and 4 (each within the scatter of the next).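

In this assay, the series now has its first direct comparison between compounds that differ in one kind of change, a 1.8-fold higher number from compound 3 to compound 4 (0.26 log units; within the scatter). Redrawing the saturated ring carbon and the saturated chain carbon together therefore leaves the read-out within the scatter, so this pair gives no sign that the combined change at these two stereocentres matters for cytotoxicity in HCT-116 cells. The comparison is a clean one, with nothing leaving and nothing entering, and it is the only one in the series so far that isolates configuration: the fact that compounds 3 and 4 differ only in the configuration as drawn

Since both stereocentres change together, the pair cannot separate them, and opposing contributions from the ring carbon and the chain carbon would look the same as no contribution from either; a compound with only one of the two redrawn would settle this. Going by these compounds, it also remains open whether the same configuration change stays as quiet once the benzyloxy group of compounds 3 and 4 gives way to a hydroxyl group, an amine or a carboxylic acid.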